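Oxime acetate to methylhydrazone on the shared core

The compounds below may be only part of what the source reports. "The series", "measured", "known", "first", "only" and "open" are said of these compounds alone.

Measured compounds and values:
- compound 1 `COc1ccc(C(O)c2ccc3c(ccn3C)c2)c(OC)c1OC`; in a functional assay on HeLa cells (Homo sapiens) for cytotoxicity, read by XTT assay, with a stated time of 72 h (on this read-out lower numbers stand for stronger inhibition and higher numbers for weaker inhibition), compound 1 gives 2400 nM
- compound 2 `CCn1ccc2cc(C(O)c3ccc(OC)c(OC)c3OC)ccc21`; in this assay compound 2 gives < 1000 nM, which is a limit of the assay and not a number
- compound 3 `COc1ccc(/C(=N\OC(C)=O)c2ccc3c(ccn3C)c2)c(OC)c1OC`; in this assay compound 3 gives 1000 nM

Compound 3 stands at the lowest of the two numbers given; its nearest neighbour is compound 1, a higher number beyond the scatter. The value of compound 2 is a limit of < 1000 nM in this assay, at which 1 of the 3 values shown sits, and is not ranked against the others.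

The next compound, compound 4 `CN/N=C(/c1ccc2c(ccn2C)c1)c1ccc(OC)c(OC)c1OC`, differs from compound 3 by methylamino in place of acetoxy on a double-bonded nitrogen.

For the measured compounds named here, only one measured step is available, an at least 2.4-fold lower number from compound 1 to compound 2 (0.38 log units; beyond the scatter), and it changes the substituent on the aromatic nitrogen, not the group on the double-bonded nitrogen. Going by the values given here, no measured step bears directly on the exchange of acetoxy for methylamino at that position. Compound 1 and compound 3 differ in more than one place, so their values show only that the oxime acetate sits at a lower number than the carbinol.

Among the compounds with values here, with no bearing step, the expected change in this assay is none beyond the scatter: the estimate for compound 4 is 1000 nM, with a range from 400 nM to 2500 nM, meaning an expected step of no change at the digits printed from compound 3 to compound 4 (within the scatter).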

Compound 4, half-maximal inhibitory concentration: 1000 nM
For compound 4 middle estimate and measured number coincide at the digits printed; the range from low to high includes it.
By their numbers in this assay, from the lowest: compounds 3 and 4 (each within the scatter of the next); then compound 1.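

In this assay, methylamino in place of acetoxy on a double-bonded nitrogen gives no change at the digits printed from compound 3 to compound 4 (within the scatter). This is the only step shown that reads this position: acetoxy, with 4 heavy atoms and 0 hydrogen-bond donors, leaves, and methylamino, with 2 heavy atoms and 1 hydrogen-bond donor, enters, with no difference beyond the scatter on this read-out, whereas the earlier step concerned only the chain on the aromatic nitrogen. The two groups therefore read alike here, but nothing shown gives a reason for this.

Still open, from the compounds shown here alone, is whether the position stays this flat with groups of another kind on the double-bonded nitrogen, such as a longer chain like butylamino, a dimethylamino group or a carboxylic acid, since acetoxy and methylamino are the only two compared there. Going by these compounds, compound 2 gives < 1000 nM, which is a limit and not a number, so it also remains open how its ethyl on the aromatic nitrogen would read together with methylamino on the double-bonded nitrogen.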